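Isobutyl for cyclobutyl on the benzylic ether carbon

This account rests on a few compounds, and the source may have more. Where it says the series, first, only, none or still open, it means among the compounds named here.

Of the compounds shown here, three sharing one core have been measured in a functional assay on cells for antagonist activity at Glucagon receptor (Homo sapiens), read by cAMP accumulation, in the presence of a further agent that is not named here; on this read-out lower numbers stand for stronger inhibition and higher numbers for weaker inhibition. Compound 1 `CCCC(Oc1ccc(-n2cc3ccccc3n2)cc1)c1ccc(C(=O)NCCC(=O)O)cc1` gives 2000 nM. Compound 2 `O=C(O)CCNC(=O)c1ccc(C(Oc2ccc(-n3cc(C(F)(F)F)cn3)cc2)C2CCC2)cc1` gives 3000 nM. Compound 3 `CCCC(Oc1ccc(-n2cccn2)cc1)c1ccc(C(=O)NCCC(=O)O)cc1` reaches only the limit of this assay, > 55000 nM; that value is a limit and not a number (the limit of > 55000 nM in this assay, at which 1 of the 3 values shown sits). Among the compounds with values here, the one step between two measured compounds that differ in a single place runs an at least 27-fold higher number from compound 1 to compound 3 (1.43 log units; beyond the scatter), a large change at the aromatic ring that sits on the phenyl ether. Among the two numbers shown, compound 2 stands highest, with compound 1 nearest to it and within the scatter, so no order between compound 2 and compound 1 can be claimed.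

Compound 4 `CC(C)CC(Oc1ccc(-n2cc(C(F)(F)F)cn2)cc1)c1ccc(C(=O)NCCC(=O)O)cc1` differs from compound 2 by isobutyl in place of cyclobutyl on a saturated chain carbon bound to an aromatic carbon and an oxygen on an aromatic ring. Within the data shown here, no measured step touches this saturated chain carbon: compounds 1 and 3 both carry propyl there and differ only at the aromatic substituent, and the change from compound 1 to compound 3 says nothing about a cyclobutyl against an isobutyl. Without a bearing step, the expected change in this assay is no change at the digits printed from compound 2 to compound 4 (within the scatter), none beyond the scatter. Compound 4 is therefore estimated at 3000 nM, with a range from 1000 nM to 9000 nM.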

Compound 4, antagonist equilibrium constant: 3400 nM
For compound 4 the middle estimate is 1.1-fold (0.05 log units) below the measured one; the range from low to high includes it.
By their numbers in this assay, from the lowest: compounds 1, 2 and 4 (each within the scatter of the next). At a limit, above all of these: compound 3.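

The earlier compounds shown here offered no step at the saturated chain carbon bound to an aromatic carbon and an oxygen on an aromatic ring, and this pair supplies the first: in this assay, isobutyl in place of cyclobutyl gives a 1.1-fold higher number from compound 2 to compound 4 (0.05 log units; within the scatter). The two groups carry the same count of heavy atoms and differ in that the four-membered ring of cyclobutyl is absent from isobutyl, so with the rest of compounds 2 and 4 held the same, the ring at this carbon can be exchanged for an open branched chain with no difference beyond the scatter. Nothing in the data shown gives a reason for this result.

As far as these compounds go, compounds 1 and 3 carry propyl at this carbon but also differ from compounds 2 and 4 at the aromatic substituent, so it remains open how propyl compares with isobutyl or cyclobutyl when the rest of the structure is held the same. Also open, from the compounds shown here alone, is whether a longer chain such as n-hexyl, a larger ring such as cyclohexyl, or an amine at this carbon would give a number in the same range.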